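This account rests on a few compounds, and the source may have more. Where it says the series, first, only, none or still open, it means among the compounds named here.

Measured so far in an ADME assay on HepG2 cells (Homo sapiens) for cytotoxicity, read by CellTiter-Glo, with a stated time of 48 h; a lower number here means that less compound is tolerated, a higher number that more compound is tolerated:
- Compound 1 (`CCCCC(=O)Nc1nc2ccccc2n1CCC`): > 50000 nM, a limit
- Compound 2 (`CCCCCCCCC(=O)Nc1nc2ccccc2n1CCC`): > 50000 nM, a limit
- Compound 3 (`CCCn1c(NC(=O)/C=C/c2ccccc2)nc2ccccc21`): 40000 nM, a number

Compound 2 gives no number and sits at the limit of > 50000 nM in this assay, at which 2 of the 3 values shown sit. Compound 4 (`CCCn1c(NC(=O)CCc2ccccc2)nc2ccccc21`) differs from it as follows: phenyl in place of hexyl on a saturated chain carbon, two bonds along the chain from a carbonyl carbon. Among the compounds with values here, the one measured step, a step that the two limits leave unreadable from compound 1 to compound 2, gives no size to carry over. Compound 3, which also holds a phenyl, reads 40000 nM, so a slight move toward less tolerated is expected at most. The expected step of an at least 1.1-fold lower number from compound 2 to compound 4 (0.04 log units; that floor lies within the scatter) stays within the scatter. The estimate for compound 4 is 45000 nM, with an expected range from 22000 nM to 80000 nM.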

Compound 4, half-maximal cytotoxic concentration: > 50000 nM
Compound 4: no number, only a limit; the forecaster's own chance of this, stated with the estimate: 55%; at least 1.1-fold (0.04 log units) between middle value and limit.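

Neither step to compound 4, from compound 1 or from compound 2, can be read in this assay: all three compounds give only limits. The compounds shown leave open whether phenyl in place of hexyl changes tolerance at all.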